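The source may report more compounds than this note shows. Statements on the series, on what has been measured and on what is new or still open speak of the compounds shown alone.

In an ADME assay on HEK293 cells (Homo sapiens) for cytotoxicity, read by MTT assay, with a stated time of 72 h (on this read-out lower numbers stand for stronger inhibition and higher numbers for weaker inhibition), compound 1 `COc1cc(C2=C(c3cc(C)c(OC)c(C)c3)C(OC(C)=O)CC2=O)cc(OC)c1OC` gives > 100 ug/mL, which is a limit of the assay and not a number. Compound 2 `COc1ccc(C2=C(c3cc(OC)c(OC)c(OC)c3)C(=O)C(O)C2)cc1F` gives > 100 ug/mL, again a limit. Compound 3 `COc1ccc(C2=C(c3cc(OC)c(OC)c(OC)c3)C(=O)CC2OC(C)=O)cc1NC=O` gives a true number, 4.16 ug/mL. Compound 1 therefore stands at the limit of > 100 ug/mL in this assay, at which 2 of the 3 values shown sit. Compound 4 `COc1cc(C2=C(c3cc(C)c(OC)c(C)c3)C(O[SiH2]C(C)(C)C)CC2=O)cc(OC)c1OC` differs from compound 1 by a single change, (a group of 5 heavy atoms (4 carbon, 1 silicon; no ring) in place of a group of 3 heavy atoms (2 carbon, 1 oxygen; no ring), on an oxygen on a saturated carbon), and the group that leaves is acetyl. Among the measured compounds shown here, the only measured step, an at least 24-fold lower number from compound 1 to compound 3 (1.38 log units; beyond the scatter), is large and beyond the scatter, but it lies on a double-bonded ring carbon, so it offers only weak guidance for a change on the oxygen. For the measured compounds named here, no measured step covers this oxygen, so a number no higher from compound 1 to compound 4 (the limit leaves the size open) is expected to stay within the scatter. For compound 4 the estimated value is 100 ug/mL, with an expected range from 30 ug/mL to 300 ug/mL.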

Compound 4, half-maximal inhibitory concentration: 29 ug/mL
Compound 4: middle estimate off by 3.4-fold (0.54 log units), on the high side; the measured number lies below the stated range.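

In this assay, the oxygen on a saturated carbon proves to be a place where a change can be seen: replacing acetyl with the group of 5 heavy atoms (4 carbon, 1 silicon) gives an at least 3.4-fold lower number from compound 1 to compound 4 (0.53 log units; beyond the scatter). This is the first step shown at this oxygen. Its full size stays unknown because compound 1 stands at a limit of the assay: the limit of > 100 ug/mL in this assay, at which 2 of the 4 values shown sit.

The compounds shown leave open whether the silicon itself matters, since no all-carbon group of similar size, such as a longer chain, or a simple methyl group, stands on this oxygen. Going by these compounds, whether the same change would act similarly on compound 3 also remains open.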